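This account rests on a few compounds, and the source may have more. Where it says the series, first, only, none or still open, it means among the compounds named here.

In an ADME assay on HepG2 cells (Homo sapiens) for cytotoxicity, with a stated time of 72 h (on this read-out lower numbers stand for an effect already at smaller amounts and higher numbers for an effect only at larger amounts of compound), compound 1 `Cc1cc(NC(=O)Nc2cccc(F)c2)c2ccccc2n1` reads > 25000 nM which is a limit and not a number. Compound 2 `COc1ccc(NC(=O)Nc2cc(C)nc3ccccc23)cc1F` reads > 25000 nM which is also a limit. Compound 3 `Cc1cc(NC(=O)Nc2cccnc2)c2ccccc2n1` reads > 25000 nM again as a limit. The whole set stands at the limit of > 25000 nM in this assay, at which 3 of the 3 values shown sit, and no number is available yet. Compound 4 `Cc1cc(NC(=O)Nc2cccc(C(C)(C)C)c2)c2ccccc2n1` differs from compound 1 by tert-butyl in place of fluoro on an aromatic carbon and keeps the rest of the structure. No size can be carried over, because a step that the two limits leave unreadable from compound 1 to compound 2 and a step that the two limits leave unreadable from compound 1 to compound 3 give none and neither involves this change. The expected outcome is a number no higher from compound 1 to compound 4 (the limit leaves the size open) with no readable step or direction expected in this assay for now. For compound 4 the estimate is 25000 nM with an expected range from 10000 nM to 50000 nM and a reading at the limit is likely.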

Compound 4, half-maximal effective concentration: > 25000 nM
Compound 4 was reported as a limit (the forecaster's own chance of this, stated with the estimate: 75%); the middle value sits exactly at the limit.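

Compound 1 and compound 4 are both reported as limits and not as numbers, so no step can be read between them. The compounds shown leave open whether any change to the shared core gives a measurable number: the limit of > 25000 nM in this assay, at which 4 of the 4 values shown sit.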